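Adding a methyl to the amine of a chromene-type core

The source may hold more compounds than are shown below. What is called first, only, known or untested is meant among the compounds shown, and "the series" means these compounds.

Compound 1 `CNCC(=O)Nc1cc(OC)ccc1C(=O)c1cc(OC)c(OC)c(OC)c1` and compound 2 `COc1ccc(C(=O)c2cc(OC)c(OC)c(OC)c2)c(NC(=O)CN(C)C)c1` share one core and differ in one place: methyl in place of hydrogen on an amine nitrogen. In a functional assay on A2780 cells (Homo sapiens) for antiproliferative activity, read by MTT assay, with a stated time of 48 h (on this read-out lower numbers stand for stronger inhibition and higher numbers for weaker inhibition), compound 1 gives 580 nM, and compound 2 gives 580 nM, so no change at the digits printed from compound 1 to compound 2 (within the scatter). Compound 3 `C=C(c1ccc2c(c1)C=CC(C)(C)O2)c1ccc(OC)cc1NC(=O)CN` has a different core; how the two cores differ is not broken down here. In this assay compound 3 gives 140 nM. Compound 4 `C=C(c1ccc2c(c1)C=CC(C)(C)O2)c1ccc(OC)cc1NC(=O)CNC` differs from compound 3 in the same kind of change: methyl in place of hydrogen on an amine nitrogen. The place is not the same, though: in compound 1 the amine nitrogen has two saturated chain carbons as other neighbours, in compound 3 only one. Because no change at the digits printed from compound 1 to compound 2 (within the scatter), the step from compound 3 to compound 4 is expected to be small, a 1.1-fold higher number from compound 3 to compound 4 (0.03 log units; within the scatter). Compound 4 is therefore estimated at 150 nM, between 60 nM and 400 nM.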

Compound 4, half-maximal inhibitory concentration: 320 nM
The estimate for compound 4 lay 2.1-fold (0.33 log units) below the measured number; measured number inside the range.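

In this assay, methyl in place of hydrogen on the amine nitrogen of the second core brings a 2.3-fold higher number from compound 3 to compound 4 (0.36 log units; beyond the scatter), a modest loss of inhibition. Set beside the step on the first core, the result does not separate the two cores: the same change on two cores in this assay, no change at the digits printed (within the scatter) from compound 1 to compound 2 and a 2.3-fold higher number (0.36 log units; beyond the scatter) from compound 3 to compound 4, 2.3-fold (0.36 log units) apart, within the scatter of two such steps. This shows no clear difference in how the change behaves on the two cores, but two pairs whose amine nitrogens have different other neighbours cannot show that it carries over unchanged throughout the series.

On these data alone, it remains open whether a longer chain such as ethyl on this nitrogen would be tolerated on either core. As far as these compounds go, how the same methyl change would behave on a third core also remains open.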